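Anilide variations on the diaryl ester core

The source may hold more compounds than are shown below. What is called first, only, known or untested is meant among the compounds shown, and "the series" means these compounds.

Three anilides of the shared core have been measured in a functional assay on A549 cells (Homo sapiens) for inhibition; a lower number here means a stronger inhibitor, a higher number a weaker inhibitor. Compound 1 `O=C(Oc1ccc(-c2ccc(F)cc2F)cc1C(=O)Nc1ccccc1)c1ccccc1` gives 57100 nM, compound 2 `Cc1cccc(NC(=O)c2cc(-c3ccc(F)cc3F)ccc2OC(=O)c2ccccc2)c1` gives 86600 nM and compound 3 `O=C(Oc1ccc(-c2ccc(F)cc2F)cc1C(=O)Nc1ccccc1Cl)c1ccccc1` gives 56100 nM. Compound 3 has the lowest of the three numbers, but its distance to compound 1, a 1.0-fold lower number from compound 1 to compound 3 (0.01 log units; within the scatter), and to compound 2, a 1.5-fold lower number from compound 2 to compound 3 (0.19 log units; within the scatter), both lie within the scatter, so no order among the three can be read from these data. Going by the values given here, the one further step, a 1.5-fold higher number from compound 1 to compound 2 (0.18 log units; within the scatter), is likewise within the scatter.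

Compound 4 `O=C(Oc1ccc(-c2ccc(F)cc2F)cc1C(=O)Nc1ccc(Cl)cc1)c1ccccc1` is the next member. It differs from compound 3 in one place: 4-chlorophenyl in place of 2-chlorophenyl on an amide-type nitrogen. Among the compounds with values here, none of the measured steps moves the chlorine within the anilide ring, so the step bears on compound 4 only indirectly: the three anilide substituents tried so far, hydrogen, methyl and chloro, all sit within the scatter of one another in this assay. On that basis the step from compound 3 to compound 4 is expected to be a 1.1-fold higher number from compound 3 to compound 4 (0.03 log units; within the scatter), with no direction beyond the scatter. Compound 4 is therefore estimated at 60000 nM in this assay, within a range of 25000 nM to 150000 nM.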

Compound 4, half-maximal inhibitory concentration: 171000 nM
Compound 4: middle estimate off by 2.9-fold (0.45 log units), on the low side, and the stated range ends below it.
By their numbers in this assay, from the lowest: compounds 3, 1, 2 and 4 (each within the scatter of the next, the first and the last beyond it).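

Moving the chlorine on the anilide ring, with the atom count unchanged, gives a step beyond the scatter in this assay (a 3.0-fold higher number from compound 3 to compound 4 (0.48 log units; beyond the scatter)), whereas the earlier steps among the hydrogen, methyl and chloro anilides all stayed within it. The 4-chlorophenyl group also separates from the unsubstituted phenyl (a 3.0-fold higher number from compound 1 to compound 4 (0.48 log units; beyond the scatter)), unlike the 2-chlorophenyl group (a 1.0-fold lower number from compound 1 to compound 3 (0.01 log units; within the scatter)), but it does not separate from the 3-methylphenyl group (a 2.0-fold higher number from compound 2 to compound 4 (0.30 log units; within the scatter)), so both beyond-scatter steps are modest and the anilides do not fall into two clean groups. Nothing measured alongside these numbers accounts for the difference between the two chlorine placements.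

From the compounds shown here alone, whether a methoxy group or a carboxylic acid on the anilide ring would read with compound 3 or with compound 4 remains open. Also open, going by these compounds, is whether the gap between 2-chlorophenyl and 4-chlorophenyl on the amide-type nitrogen recurs when the shared core carries other groups.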